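The source may hold more compounds than are shown below. What is called first, only, known or untested is meant among the compounds shown, and "the series" means these compounds.

In an ADME assay on BJ cells (Homo sapiens) for antiproliferative activity, with a stated time of 72 h (a lower number here means that less compound is needed, a higher number that more compound is needed for the effect), compound 1 `C=CCNC(=O)n1c(-c2ccc(OC)cc2)cc(=O)c2c(OC)cc(OC)cc21` gives 74000 nM. Compound 2 `COc1ccc(-c2cc(=O)c3c(OC)cc(OC)cc3n2S(=O)(=O)c2cccc([N+](=O)[O-])c2)cc1` reaches only a limit of the assay, > 39600 nM. Compound 3 `COc1ccc(-c2cc(=O)c3c(OC)cc(OC)cc3n2S(=O)(=O)c2ccc(C)c([N+](=O)[O-])c2)cc1` likewise reaches only a limit of the assay, > 51700 nM. The step that the two limits leave unreadable from compound 2 to compound 3 therefore cannot be read, since both of its ends sit at limits the limit of > 39600 nM in this assay, at which 1 of the 3 values shown sits, and (the limit of > 51700 nM in this assay, at which 1 of the 3 values shown sits). Compound 3 thus stands on a limit, one of the two limits among the three values shown, and the only number shown is the one for compound 1.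

Compound 4 `COc1ccc(-c2cc(=O)c3c(OC)cc(OC)cc3n2S(=O)(=O)c2cccc(Br)c2)cc1` differs from compound 3 by 3-bromophenyl in place of 4-methyl-3-nitrophenyl on a sulfonyl sulfur. Going by the values given here, no measured step follows a change on the sulfonyl sulfur, and the single measured step that the two limits leave unreadable from compound 2 to compound 3 gives no readable size. With all three values sitting at or near the top of the measured range, the expectation for compound 4 in this assay is no step beyond the scatter, a step that the limit leaves unreadable from compound 3 to compound 4. Compound 4 is estimated at 70000 nM, between 30000 nM and 200000 nM, with a real chance that only a limit is reported.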

Compound 4, half-maximal effective concentration: > 58600 nM
Compound 4 was reported as a limit; the forecaster's own chance of this, stated with the estimate: 60%; the middle value is on the limit's open side.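

Compound 4 stands only at a limit of the assay in this assay, and its steps from compound 1, compound 2 and compound 3 cannot be read. The compounds shown leave open whether any change on the sulfonyl sulfur shifts the value in this assay at all.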